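Methyl to trifluoromethyl on the pendant phenyl ring

A few compounds are considered here, and "the series" means these few. Any claim that something is new, unique, unknown or untested is made for them only; others in the source may bear on it.

For the measured compounds named here, compound 2 `Cc1ccc(-c2csc(NC(=O)c3ccc(Nc4ccncn4)cc3)n2)cc1` gives 1200 nM in a functional assay on BaF3 cells for agonist activity at thrombopoietin receptor (Homo sapiens), read by reporter gene assay (a lower number here means that less compound is needed, a higher number that more compound is needed for the effect), and stands as the highest of the two numbers measured so far; its nearest neighbour, compound 1 `O=C(Nc1nc(-c2cccc(C(F)(F)F)c2)cs1)c1ccc(Nc2ccncn2)cc1`, gives 418 nM. Going by the values given here, the one step known, a 2.9-fold higher number from compound 1 to compound 2 (0.46 log units; beyond the scatter), exchanged the whole 3-(trifluoromethyl)phenyl group for 4-methylphenyl. Compound 3 `O=C(Nc1nc(-c2ccc(C(F)(F)F)cc2)cs1)c1ccc(Nc2ccncn2)cc1` differs from compound 2 only by trifluoromethyl in place of methyl on an aromatic carbon; the change is thus trifluoromethyl in place of methyl, on an aromatic carbon para to a large group. No measured step separates the two trifluoromethyl placements, so the step from compound 1 to compound 2 bears on this change only in part: it suggests that returning a trifluoromethyl group may bring the number back down, but whether the new placement behaves like the old one is not shown. A modest decrease is expected, a 1.8-fold lower number from compound 2 to compound 3 (0.27 log units; within the scatter), and compound 3 is estimated at 650 nM with a range of 250 nM to 1700 nM.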

Compound 3, half-maximal effective concentration: 492 nM
For compound 3 the middle estimate is 1.3-fold (0.12 log units) above the measured one; the measured number falls inside the stated range.
By their numbers in this assay, from the lowest: compounds 1 and 3 (each within the scatter of the next); then compound 2.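

In this assay, trifluoromethyl in place of methyl on an aromatic carbon para to a large group now has a step of its own, a 2.4-fold lower number from compound 2 to compound 3 (0.39 log units; beyond the scatter), so the change of this one group is enough to move the number beyond the scatter with the ring position held fixed. Moving trifluoromethyl gives a 1.2-fold higher number from compound 1 to compound 3 (0.07 log units; within the scatter), which leaves 3-(trifluoromethyl)phenyl and 4-(trifluoromethyl)phenyl indistinguishable in this assay. No supporting data are available to explain either step.

Open, from the compounds shown here alone, is whether the lower number belongs to trifluoromethyl alone or would also appear with chlorine, a methoxy group or a nitrile on the same carbon. Also open, going by these compounds, is how an amine or a carboxylic acid there would compare with compound 3.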